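Chain Length at the Acid End of an Aryloxy Pyridine

The source may hold more compounds than are shown below. What is called first, only, known or untested is meant among the compounds shown, and "the series" means these compounds.

Measured so far:
Compound 1, `N#Cc1ccc(Nc2cnccc2SCc2ccccc2C(=O)O)c2ccccc12`, gives 240 nM in an assay on HEK293 cells for inhibition of solute carrier family 22 member 12 (Homo sapiens), read by scintillation counting, with stated times of 30 min and 15 min; on this read-out higher numbers stand for weaker inhibition and lower numbers for stronger inhibition.
Compound 2, `N#Cc1ccc(Oc2cnccc2SCCCCC(=O)O)c2ccccc12`, gives 4220 nM in this assay.
Compound 3, `CN(c1cnccc1SCCCCCC(=O)O)c1ccc(C#N)c2ccccc12`, gives 3760 nM in this assay.

Compound 2 carries the highest number of the three in this assay, which on this read-out means the weakest inhibition shown. Its nearest neighbour is compound 3, whose number lies within the usual scatter of compound 2, so the two cannot be told apart. Compound 1 stands furthest away, with a number well below that of compound 2 and beyond the scatter.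

Compound 4, `N#Cc1ccc(Oc2cnccc2SCCCCCC(=O)O)c2ccccc12`, has not yet been measured. It differs from compound 2 in one place: carboxymethyl in place of carboxy on a saturated chain carbon, four bonds along the chain from a sulfur. The change lengthens the saturated chain between the sulfur and the acid.

For the measured compounds named here, no pair of measured compounds shows this exact step on its own. Compound 3 carries the longer chain but also a different linker to the core, and its number sits within the scatter of compound 2, so there is no sign that chain length alone moves the read-out. The step from compound 2 to compound 4 is therefore expected to be small, a 1.2-fold lower number from compound 2 to compound 4 (0.07 log units; within the scatter), not clearly beyond the scatter in either direction. Compound 4 is estimated at 3600 nM, with a range from 1500 nM to 9000 nM.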

Compound 4, half-maximal inhibitory concentration: 4740 nM
Estimate against measurement, compound 4: 1.3-fold (0.12 log units) below; the range from low to high includes it.
By their numbers in this assay, from the lowest: compound 1; then compounds 3, 2 and 4 (each within the scatter of the next).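

In this assay, putting carboxymethyl in place of carboxy on a saturated chain carbon, four bonds along the chain from a sulfur, gives a 1.1-fold higher number from compound 2 to compound 4 (0.05 log units; within the scatter) and so leaves the two compounds indistinguishable. For the compounds shown here, this is the first pair in which the chain grows with nothing else altered, so the lack of a clear shift can now be tied to this single change, though only for this one pair and this one added carbon. Nothing measured here explains why the read-out shows no clear response to the longer chain, and no supporting data bear on the question.

As far as these compounds go, whether the same holds for a shorter chain, such as 3-carboxypropyl on the sulfur, for a still longer chain, or for this chain with a different linker to the shared core remains open. Also open, from the compounds shown here alone, is whether the carboxylic acid itself matters at this chain length, which a primary amide or a tetrazole at the chain end could test in a way that changing the length alone cannot.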